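Notes on compound 3, following the step from compound 1

The compounds below may be only part of what the source reports. "The series", "measured", "known", "first", "only" and "open" are said of these compounds alone.

Measured in an assay on DDT1 cells (Cricetulus griseus) for binding affinity to adenosine receptor A1 (Homo sapiens), read by radioligand binding; a lower number here means a stronger inhibitor, a higher number a weaker inhibitor:
compound 1, `CCCCNC(=O)OC[C@H]1OC(n2cnc3c(NC4CCOC4)ncnc32)[C@H](O)[C@@H]1O`: 1410 nM
compound 2, `O=C(NC1CC1)OC[C@H]1OC(n2cnc3c(NC4CCOC4)ncnc32)[C@H](O)[C@@H]1O`: 209 nM

Among the compounds with values here, compound 1 gives the highest of the two numbers; its nearest neighbour is compound 2, and the step of a 6.7-fold lower number from compound 1 to compound 2 (0.83 log units; beyond the scatter) is the only measured step in the set.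

Compound 3, `C=CC/N=C(\S)OC[C@H]1OC(n2cnc3c(NC4CCOC4)ncnc32)[C@H](O)[C@@H]1O`, is not yet measured. It differs from compound 1 by a group of 6 heavy atoms (4 carbon, 1 nitrogen, 1 sulfur; no ring) in place of a group of 7 heavy atoms (5 carbon, 1 nitrogen, 1 oxygen; no ring), on an oxygen on a saturated carbon. Within the data shown here, the one measured step bears on it only loosely: it also alters the butylcarbamoyl region, but there the change stayed within an amide-type arrangement, whereas in compound 3 the whole butylcarbamoyl group gives way to an acyclic group carrying sulfur and two double bonds outside aromatic rings. Among the measured compounds shown here, a change in this assay of modest size is expected, in the downward direction seen from compound 1 to compound 2, but with wide uncertainty since no compound shows the entering group. For compound 3 the expected step is a 1.8-fold lower number from compound 1 to compound 3 (0.25 log units; within the scatter), giving an estimate of 800 nM with a range from 200 nM to 3200 nM.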

Compound 3, inhibition constant: 35 nM
The estimate for compound 3 lay 23-fold (1.36 log units) above the measured number; the whole stated range lies above it.
By their numbers in this assay, from the lowest: compound 3; then compound 2; then compound 1.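

Within the data shown here, at the oxygen on a saturated carbon, this assay does not require the amide-type arrangement of the earlier compounds: the acyclic sulfur-carrying group comes with a 40-fold lower number from compound 1 to compound 3 (1.61 log units; beyond the scatter). It also goes lower than the cyclopropyl-bearing group, with a 6.0-fold lower number from compound 2 to compound 3 (0.78 log units; beyond the scatter), so a three-membered ring is not needed for a low number at this place. The entering group differs from the butylcarbamoyl group in its sulfur and in its extra double bond, and no data in hand explain the drop.

Still open is whether the sulfur or the carbon-carbon double bond accounts for the step, as no compound shown carries one without the other. A saturated propyl chain in place of the unsaturated chain, or a carbonyl oxygen in place of the sulfur, would separate the two.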